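Thiourea replacements for the benzyl group on the ring amine

The source may report more compounds than this note shows. Statements on the series, on what has been measured and on what is new or still open speak of the compounds shown alone.

Measured compounds:
compound 1 `Cc1ccccc1CN1CCc2c(sc(NC(=O)c3ccccc3Cl)c2C(N)=O)C1` — > 50000 nM
compound 2 `NC(=O)c1c(NC(=O)c2ccccc2Cl)sc2c1CCN(C(=S)Nc1ccccc1I)C2` — 4430 nM
compound 3 `COc1ccccc1NC(=S)N1CCc2c(sc(NC(=O)c3ccccc3Cl)c2C(N)=O)C1` — 40900 nM

For the measured compounds named here, in a functional assay on HL-60 cells (Homo sapiens) for antiproliferative activity, with a stated time of 24 h (on this read-out higher numbers stand for weaker inhibition and lower numbers for stronger inhibition), compound 1 gives only a limit, > 50000 nM; it is the one compound sitting at the limit of > 50000 nM in this assay, at which 1 of the 3 values shown sits. Compound 4 `COc1ccc(NC(=S)N2CCc3c(sc(NC(=O)c4ccccc4Cl)c3C(N)=O)C2)cc1` is not yet measured. It differs from compound 1 by a group of 11 heavy atoms (8 carbon, 1 nitrogen, 1 oxygen, 1 sulfur; one six-membered aromatic ring of carbon only) in place of a group of 8 heavy atoms (8 carbon; one six-membered aromatic ring of carbon only), on an amine nitrogen in a ring.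

Going by the values given here, two measured steps bear on this change, both starting from compound 1 and both putting a group of the same kind onto the same ring amine. With iodo on the aromatic ring the step was an at least 11-fold lower number from compound 1 to compound 2 (1.05 log units; beyond the scatter). With methoxy on the aromatic ring the step was an at least 1.2-fold lower number from compound 1 to compound 3 (0.08 log units; that floor lies within the scatter), and between those two compounds the swap of methoxy in place of iodo gave a 9.2-fold higher number from compound 2 to compound 3 (0.97 log units; beyond the scatter). Compound 4 carries methoxy, so compound 3 is the closer reference; the change is expected to give a number lower than the limit of compound 1, but by a step of uncertain size, estimated as an at least 1.6-fold lower number from compound 1 to compound 4 (0.22 log units; that floor lies within the scatter). For compound 4 the expected value in this assay is 30000 nM, within a range of 8000 nM to 100000 nM.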

Compound 4, half-maximal inhibitory concentration: 15700 nM
Compound 4: middle estimate off by 1.9-fold (0.28 log units), on the high side; measured number inside the range.
By their numbers in this assay, from the lowest: compound 2; then compound 4; then compound 3. At a limit, above all of these: compound 1.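

In this assay, 4-methoxyphenyl in place of 2-methoxyphenyl on the thiourea gives a 2.6-fold lower number from compound 3 to compound 4 (0.42 log units; beyond the scatter), so with the same methoxy group, where it sits on the aromatic ring changes the number, which the iodo and methoxy pair of compound 2 and compound 3 could not show. The thiourea step from the 2-methylbenzyl group now reads beyond the scatter as an at least 3.1-fold lower number from compound 1 to compound 4 (0.50 log units; beyond the scatter), while a 3.5-fold higher number from compound 2 to compound 4 (0.55 log units; beyond the scatter) leaves the 2-iodophenyl compound with the lowest number of the series. Compound 1 remains a limit and not a number: the limit of > 50000 nM in this assay, at which 1 of the 4 values shown sits.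

Open, on these data alone, is how much of the step belongs to the thiourea itself and how much to the substituent on its aromatic ring. An unsubstituted phenyl, a urea in place of the thiourea, or a carboxylic acid on the aromatic ring would separate these.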